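Methyl in Place of Bromo on the Triazole Phenyl Ring

The source may hold more compounds than are shown below. What is called first, only, known or untested is meant among the compounds shown, and "the series" means these compounds.

Compound 1, `C=C1C(=O)[C@]23C[C@@]1(O)CC[C@H]2c1ccc(OS(=O)(=O)c2ccc(C)cc2)c(C)c1[C@@H]3Cn1cc(-c2ccc(Cl)cc2)nn1`, gives 2390 nM in a functional assay on SW480 cells (Homo sapiens) for cytotoxicity, read by MTT assay, with a stated time of 4 days; on this read-out higher numbers stand for weaker inhibition and lower numbers for stronger inhibition.
Compound 2, `C=C1C[C@]23C[C@@]1(O)CC[C@H]2c1ccc(O)c(C)c1[C@@H]3Cn1cc(-c2ccc(C(F)(F)F)cc2)nn1`, reaches only the limit of this assay, reported as > 20000 nM.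
Compound 3, `C=C1C[C@]23C[C@@]1(O)CC[C@@H]2c1cccc(C)c1[C@@H]3Cn1cc(-c2ccc(Br)cc2)nn1`, also reaches only the limit of this assay, reported as > 20000 nM.

For the measured compounds named here, compound 3 therefore stands at the edge of what this assay can report, with no number of its own; the same is true of compound 2, and the only compound with a numerical value is compound 1. This matches (the limit of > 20000 nM in this assay, at which 2 of the 3 values shown sit).

Compound 4, `C=C1C[C@]23C[C@@]1(O)CC[C@@H]2c1cccc(C)c1[C@@H]3Cn1cc(-c2ccc(C)cc2)nn1`, is not yet measured. It differs from compound 3 in one place: methyl in place of bromo on an aromatic carbon. The group that leaves and the group that enters are each of a single heavy atom, without ring, donor, acceptor or charge, and the rest of the shared core is unchanged. Going by the values given here, with no measured step of this kind among the three compounds, the expectation is that the change brings no shift beyond the usual scatter, and that compound 4, like compound 3, will most likely be reported only as a limit. The step from compound 3 to compound 4 is expected to be a step that the limit leaves unreadable from compound 3 to compound 4. Compound 4 is estimated at 25000 nM, within a range from 8000 nM to 80000 nM.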

Compound 4, half-maximal inhibitory concentration: > 20000 nM
Compound 4: a limit, no number; the forecaster's own chance of this, stated with the estimate: 75%; the middle value is on the limit's open side.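

Compound 3 and compound 4 each sit at a limit of this assay and have no number of their own, so no step can be read between them: the limit of > 20000 nM in this assay, at which 3 of the 4 values shown sit.

The compounds shown leave open whether changing 4-bromophenyl to 4-methylphenyl on the shared core alters cytotoxicity at all.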